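A Fluorine Moved on the Sulfonamide Phenyl

A few compounds are considered here, and "the series" means these few. Any claim that something is new, unique, unknown or untested is made for them only; others in the source may bear on it.

Compound 3 `CC(C)CN(c1cccc(F)c1)S(=O)(=O)c1ccc2c(c1)C(=O)CC(C1CCOCC1)O2` gives 3.5 in a physicochemical assay for lipophilicity, at pH 7.4 (on this read-out lower numbers stand for lower lipophilicity and higher numbers for higher lipophilicity), the second highest of the three values: compound 2 `CC(C)CN(c1ccc(F)cc1)S(=O)(=O)c1ccc2c(c1)C(=O)CC(C1CCOCC1)O2` lies nearest with 3.48, a gap within the scatter, while compound 1 `CC(C)CN(Cc1ccccc1C(F)(F)F)S(=O)(=O)c1ccc2c(c1)C(=O)CC(C1CCOCC1)O2` stands furthest with 4.32. The steps of a number 0.84 log units lower from compound 1 to compound 2 (beyond the scatter) and a number 0.82 log units lower from compound 1 to compound 3 (beyond the scatter) are both beyond the scatter, whereas a number 0.02 log units higher from compound 2 to compound 3 (within the scatter) is not. Compound 4 `CC(C)CN(c1ccccc1F)S(=O)(=O)c1ccc2c(c1)C(=O)CC(C1CCOCC1)O2` differs from compound 3 in one place: 2-fluorophenyl in place of 3-fluorophenyl on a sulfonamide nitrogen. Among the measured compounds shown here, the one measured step that bears on this change, a number 0.02 log units higher from compound 2 to compound 3 (within the scatter), also exchanged one fluorophenyl for another on the sulfonamide nitrogen and stayed within the scatter, so no step beyond the scatter is expected here. Compound 4 is therefore estimated at 3.5 in this assay, between 3.2 and 3.8, an expected step of no change at the digits printed from compound 3 to compound 4 (within the scatter).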

Compound 4, distribution coefficient: 3.44
For compound 4 the middle estimate is 0.06 log units above the measured one; measured number inside the range.
By their numbers in this assay, from the lowest: compounds 4, 2 and 3 (each within the scatter of the next); then compound 1.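

With 2-fluorophenyl on the sulfonamide nitrogen, the reading in this assay completes the set of three fluorophenyl compounds, which all lie within the scatter of one another: a number 0.06 log units lower from compound 3 to compound 4 (within the scatter) and a number 0.04 log units lower from compound 2 to compound 4 (within the scatter). Compound 4 also keeps the distance from the 2-(trifluoromethyl)benzyl compound seen for the other two, with a number 0.88 log units lower from compound 1 to compound 4 (beyond the scatter). Nothing available explains these readings. The compounds shown leave open whether an unsubstituted phenyl, or a phenyl carrying a nitrile or an amine, would stay with this group on the same nitrogen.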